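A few compounds are considered here, and "the series" means these few. Any claim that something is new, unique, unknown or untested is made for them only; others in the source may bear on it.

Measured compounds:

compound 1 `CC[C@H](C)[C@H](NC(=O)N1CCC2(CC1)CN(C)C2c1ccc(Cl)cc1)C(=O)OC`: 410 nM
compound 2 `CC[C@H](C)[C@H](NC(=O)N1CCC2(CC1)C(=O)N(C)C2c1ccc(Cl)cc1)C(=O)OC`: 800 nM
compound 3 `CC[C@H](C)[C@H](NC(=O)N1CCC2(CC1)CN(C(C)C)C2c1ccc(F)cc1)C(=O)OC`: 256 nM

All three share one spirocyclic urea core and the same amino-ester portion on the urea; they differ in the substituent on the basic nitrogen, in a carbonyl on that ring, and in the halogen on the pendant phenyl. In an assay on HEK293 cells for inhibition of Voltage-dependent T-type calcium channel subunit alpha-1H (Homo sapiens), read by patch clamp, using a membrane potential dye (on this read-out lower numbers stand for stronger inhibition and higher numbers for weaker inhibition), compound 3 gives 256 nM, the lowest number of the three. The value of compound 1 in this assay, 410 nM, sits within the scatter of that of compound 3, so no order between the two can be claimed. Compound 2, at 800 nM, stands beyond the scatter above compound 3.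

Compound 4 `CC(C)N1CC2(CCN(C(=O)Nc3cc(F)cc(F)c3)CC2)C1c1ccc(F)cc1` has not been measured in this assay. The change from compound 3 is 3,5-difluorophenyl in place of 1-(methoxycarbonyl)-2-methylbutyl on an amide-type nitrogen. Among the compounds with values here, no measured pair in the set carries a change of this kind, so nothing in the data tells the direction or size of such a step. The expectation is therefore a step of a 1.2-fold lower number from compound 3 to compound 4 (0.07 log units; within the scatter), not beyond the scatter, with wide uncertainty on both sides. On that basis compound 4 is estimated at 220 nM in this assay, in the range 50 nM to 900 nM.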

Compound 4, half-maximal inhibitory concentration: 172 nM
Compound 4: the middle estimate sits 1.3-fold (0.11 log units) above what was measured; measured number inside the range.
By their numbers in this assay, from the lowest: compounds 4, 3, 1 and 2 (each within the scatter of the next, the first and the last beyond it).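

In this assay, 3,5-difluorophenyl in place of 1-(methoxycarbonyl)-2-methylbutyl on the amide-type nitrogen gives a 1.5-fold lower number from compound 3 to compound 4 (0.17 log units; within the scatter), so this exchange causes no change that can be told from the scatter. Compounds 1, 2 and 3 all carry the same amino-ester portion on the urea and so say nothing about this position; compound 4 shows that a number in this range does not depend on the ester, its two defined stereocentres or the open chain, and that a six-membered aromatic ring of carbon only is tolerated there. Nothing available bears on why the two groups read alike in this assay.

Still open, as far as these compounds go, is whether the two fluorines matter, which an unsubstituted phenyl or a 3,5-dichlorophenyl at the same place would test, and whether a carboxylic acid or a primary amide in place of the methyl ester would hold the number. The exchange is also shown on the core of compound 3 only, so its outcome on the cores of compound 1 and compound 2 remains unknown.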